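From 2-Bromophenyl to 2,5-Dichlorophenyl on Compound 2

The source may hold more compounds than are shown below. What is called first, only, known or untested is meant among the compounds shown, and "the series" means these compounds.

Compound 1 `COc1ccc(-n2nncc2CN2C(=O)C3(C(C#N)=C(N)Oc4c3c3nc5ccccc5nc3c3ccccc43)c3ccccc32)cc1`: > 50000 nM
Compound 2 `N#CC1=C(N)Oc2c(N)cc3nc4ccccc4nc3c2C12C(=O)N(Cc1cnnn1-c1ccccc1Br)c1ccccc12`: 12400 nM

Of the compounds shown here, two have been tested in a functional assay on HCT-116 cells (Homo sapiens) for antiproliferative activity, read by MTT assay, with a stated time of 48 h; a lower number here means a stronger inhibitor, a higher number a weaker inhibitor. For compound 1 the result is a limit of the assay, > 50000 nM, recorded as the limit of > 50000 nM in this assay, at which 1 of the 2 values shown sits. Among the measured compounds shown here, compound 2 gives 12400 nM in this assay, the only actual number among the results so far, so it stands alone and cannot be ranked against a measured neighbour. Compound 3 `N#CC1=C(N)Oc2c(N)cc3nc4ccccc4nc3c2C12C(=O)N(Cc1cnnn1-c1cc(Cl)ccc1Cl)c1ccccc12` has not yet been measured. It differs from compound 2 in a single place: 2,5-dichlorophenyl in place of 2-bromophenyl on an aromatic nitrogen. For the measured compounds named here, because no step between measured compounds exists in these data, the effect of such a change in this assay is unknown here. Exchanging one halogenated phenyl for another is expected to move the value by no more than the usual scatter, in no particular direction. Compound 3 is therefore expected to give about 11000 nM, within 4000 nM to 35000 nM, in this assay. The expected step of a 1.1-fold lower number from compound 2 to compound 3 (0.05 log units; within the scatter) is thus small.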

Compound 3, half-maximal inhibitory concentration: > 50000 nM
Compound 3: a limit, no number (the forecaster's own chance of this, stated with the estimate: 15%); at least 4.5-fold (0.65 log units) between middle value and limit.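

In this assay compound 3 gives > 50000 nM, which is a limit of the assay and not a number. Among the compounds shown here, the aromatic nitrogen of the five-membered ring is thus a place where the choice of halogenated phenyl matters: 2,5-dichlorophenyl in place of 2-bromophenyl gives an at least 4.0-fold higher number from compound 2 to compound 3 (0.60 log units; beyond the scatter), the first step that can be read in this set. Its full size stays unknown, and the measured result again falls at the ceiling of the read-out: the limit of > 50000 nM in this assay, at which 2 of the 3 values shown sit.

On these data alone, it remains open whether the step follows from chlorine replacing bromine or from the second halogen, a question that a phenyl carrying one chlorine would help to settle. As far as these compounds go, it is also open how an unsubstituted phenyl, or a phenyl bearing an amine or a carboxylic acid, would read at this place.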